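The source may report more compounds than this note shows. Statements on the series, on what has been measured and on what is new or still open speak of the compounds shown alone.

Measured so far in a functional assay on A549 cells (Homo sapiens) for cytotoxicity, read by MTT assay, with a stated time of 72 h; on this read-out higher numbers stand for weaker inhibition and lower numbers for stronger inhibition:

compound 1, `COc1cccc(/C=C2\CCC/C(=C\c3cc(Cl)cc(Cl)c3)C2=O)c1OC`, 12500 nM
compound 2, `COc1cccc(/C=C2\CCC/C(=C\c3ccc(O)c(Cl)c3)C2=O)c1OC`, > 20000 nM
compound 3, `COc1ccc(/C=C2\CCC/C(=C\c3cc(Cl)cc(Cl)c3)C2=O)cc1OC`, 5500 nM

In this assay compound 1 gives 12500 nM. For compound 2 the read-out is a limit of the assay, not a number: > 20000 nM. One of the three values shown sits at this limit, (the limit of > 20000 nM in this assay, at which 1 of the 3 values shown sits). Compound 3 gives 5500 nM, the lower of the two numbers, and its gap to compound 1 lies beyond the usual scatter.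

Compound 2 differs from compound 1 in one place: 3-chloro-4-hydroxyphenyl in place of 3,5-dichlorophenyl on a double-bonded chain carbon bound to a double-bonded ring carbon. That change produced an at least 1.6-fold higher number from compound 1 to compound 2 (0.20 log units; that floor lies within the scatter), and since the result for compound 2 is only a limit, the true size of the step may be larger. Compound 1 and compound 3 are built from the same atoms joined differently; the difference between the two cores is not broken down here.

Compound 4, `COc1ccc(/C=C2\CCC/C(=C\c3ccc(O)c(Cl)c3)C2=O)cc1OC`, has not yet been measured. It differs from compound 3 by 3-chloro-4-hydroxyphenyl in place of 3,5-dichlorophenyl on a double-bonded chain carbon bound to a double-bonded ring carbon, the same change that turned compound 1 into compound 2. The step from compound 3 to compound 4 is expected to be a 2.5-fold higher number from compound 3 to compound 4 (0.41 log units; beyond the scatter) in this assay, resting on the earlier step, an at least 1.6-fold higher number from compound 1 to compound 2 (0.20 log units; that floor lies within the scatter), whose floor was set by a limit. Compound 4 is therefore expected to come out near 14000 nM in this assay, between about 6000 nM and 40000 nM, with a real chance that only a limit is reported.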

Compound 4, half-maximal inhibitory concentration: > 20000 nM
Compound 4: a limit, no number; the forecaster's own chance of this, stated with the estimate: 40%; middle value at least 1.4-fold (0.15 log units) from the limit.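

In this assay, putting 3-chloro-4-hydroxyphenyl in place of 3,5-dichlorophenyl on the second core gives an at least 3.6-fold higher number from compound 3 to compound 4 (0.56 log units; beyond the scatter). For compound 4 the result is a limit of the assay and not a number: > 20000 nM. So on both cores the change points towards a higher number, which means weaker inhibition, and this step clears the usual scatter while the earlier floor does not, yet this does not show that the change has the same size on each core, nor how large either step really is: the same change on two cores in this assay, an at least 1.6-fold higher number (0.20 log units; that floor lies within the scatter) from compound 1 to compound 2 and an at least 3.6-fold higher number (0.56 log units; beyond the scatter) from compound 3 to compound 4; the limit leaves it open whether they differ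

The compounds shown leave open which part of the swap matters, the hydroxy group that enters or the chlorine that leaves, as both happen together in each pair and neither is seen alone. They also leave open whether another group on this ring, such as an amine or a carboxylic acid, would give a readable number in this assay, and whether the same change would push the read-out the same way on a core other than these two.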